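The source may report more compounds than this note shows. Statements on the series, on what has been measured and on what is new or still open speak of the compounds shown alone.

Compound 3 `COc1cc(-n2cnc3ccc(-c4ccc(O)cc4)cc32)cc(OC)c1OC` gives 5090 nM in a functional assay on A549 cells (Homo sapiens) for antiproliferative activity, read by MTT assay, with a stated time of 72 h (a higher number here means a weaker inhibitor, a lower number a stronger inhibitor), the higher of the two numbers measured; the other belongs to compound 1 `COc1cc(-n2cnc3ccc(-c4cccc(N)c4)cc32)cc(OC)c1OC`, which gives 640 nM. Compound 2 `COc1ccc(-c2ccc3ncn(-c4cc(OC)c(OC)c(OC)c4)c3c2)cc1` does not reach a number in this assay but only the limit > 10000 nM (the limit of > 10000 nM in this assay, at which 1 of the 3 values shown sits). Compound 4 `COc1ccc(-c2ccc3ncn(-c4cc(OC)c(OC)c(OC)c4)c3c2)cc1O` differs from compound 3 by 3-hydroxy-4-methoxyphenyl in place of 4-hydroxyphenyl on an aromatic carbon. The step that bears on this change is an at least 1.9-fold lower number from compound 2 to compound 3 (0.29 log units; that floor lies within the scatter). Compound 4 keeps the methyl on oxygen that compound 2 carries and adds a hydroxyl. That step was small, so only a modest shift is foreseen, with a real chance that a limit is reported. The expected step is a 1.4-fold higher number from compound 3 to compound 4 (0.14 log units; within the scatter). Compound 4 is therefore estimated at 7000 nM, within a range from 2500 nM to 20000 nM.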

Compound 4, half-maximal inhibitory concentration: 200 nM
Compound 4: middle estimate off by 35-fold (1.54 log units), on the high side; the measured number lies below the stated range.
By their numbers in this assay, from the lowest: compound 4; then compound 1; then compound 3. At a limit, above all of these: compound 2.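

Adding one hydroxy to the 4-methoxyphenyl group brings an at least 50-fold lower number from compound 2 to compound 4 (1.69 log units; beyond the scatter), so this position responds strongly to a small change. The 3-hydroxy-4-methoxyphenyl group also outperforms both other groups with a number, with a 25-fold lower number from compound 3 to compound 4 (1.41 log units; beyond the scatter) and a 3.2-fold lower number from compound 1 to compound 4 (0.51 log units; beyond the scatter). Compound 2 itself has only a limit, not a number: the limit of > 10000 nM in this assay, at which 1 of the 4 values shown sits.

Whether the gain needs a hydroxy in particular stays open, since a fluorine or a carboxylic acid in its place is not among the compounds shown. Going by these compounds, whether the 4-methoxy group is also needed stays open too.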